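The source may report more compounds than this note shows. Statements on the series, on what has been measured and on what is new or still open speak of the compounds shown alone.

Working notes on the quinoline series, single change at a time.

Compound 1 is `COc1ccc2nc(C)cc(OCc3ccc4ccccc4n3)c2c1` and in a toxicity assay on HepG2 cells (Homo sapiens) for inhibition, read by CellTiter-Glo, with a stated time of 48 h (on this read-out higher numbers stand for weaker inhibition and lower numbers for stronger inhibition), compound 1 gives 31600 nM. Compound 2, `COc1ccc2nc(C)cc(OCC(=O)Nc3cc(C)c(OC)c(C)c3)c2c1`, carries the acetamide linker to a 4-methoxy-3,5-dimethylphenyl group and in this assay compound 2 gives 7940 nM. Compound 3 is `COc1ccc2nc(C)cc(OCC(=O)Nc3cc(C)c(F)c(C)c3)c2c1`. In this assay compound 3 reaches only a limit, > 100000 nM, so its position is known just as a bound and not as a number. Within the data shown here, the one measured step, an at least 12-fold higher number from compound 2 to compound 3 (1.10 log units; beyond the scatter), runs to that bound; it is read against (the limit of > 100000 nM in this assay, at which 1 of the 3 values shown sits), so its true size is open above.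

Compound 4 is `COc1ccc2nc(C)cc(OCC(=O)Nc3ccncn3)c2c1`. The change from compound 3 is pyrimidin-4-yl in place of 4-fluoro-3,5-dimethylphenyl on an amide-type nitrogen. Among the measured compounds shown here, no measured step exchanges the whole aryl group on the amide nitrogen; the step from compound 2 to compound 3 is the only one on that side of the molecule, and it moved a single substituent on the ring that now leaves, not the ring itself. It therefore bears on this step only loosely. The expectation for compound 4 is weak inhibition, with a chance of another limit, and the estimated step of an at least 1.2-fold lower number from compound 3 to compound 4 (0.09 log units; that floor lies within the scatter) is expected to lie within the scatter. Compound 4 is estimated at 80000 nM, with a range from 20000 nM to 200000 nM.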

Compound 4, half-maximal inhibitory concentration: > 100000 nM
Compound 4 gave a limit, no number; the forecaster's own chance of this, stated with the estimate: 50%; at least 1.2-fold (0.09 log units) between middle value and limit.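

In this assay compound 4 gives only a limit, > 100000 nM. Compound 3 sits at a limit as well, so no step can be read between compound 3 and compound 4: the limit of > 100000 nM in this assay, at which 2 of the 4 values shown sit. The compounds shown leave open whether pyrimidin-4-yl or 4-fluoro-3,5-dimethylphenyl on the amide-type nitrogen gives the weaker inhibition.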